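Lengthening the aminoalkyl chain in a T-type calcium channel series

A few compounds are considered here, and "the series" means these few. Any claim that something is new, unique, unknown or untested is made for them only; others in the source may bear on it.

The study concerns a set of closely related compounds tested in an assay on HEK293 cells for inhibition of Voltage-dependent T-type calcium channel subunit alpha-1G (Homo sapiens), read by patch clamp; on this read-out higher numbers stand for weaker inhibition and lower numbers for stronger inhibition. Compound 1 `CN(C)CCCCCN(C)C1=Nc2ccccc2C(CC(=O)NCc2ccccc2)N1c1ccc(-c2ccccn2)cc1` carries a longer chain than compound 2 and a different distal aryl group; in this assay compound 1 gives "not determined" (no result reported), so no result was reported for it. Among the measured compounds shown here, compound 2 `CN(C)CCCCN(C)C1=Nc2ccccc2C(CC(=O)NCc2ccccc2)N1c1ccc(-c2ccccc2)cc1` is therefore the only compound of the set with a number: in this assay compound 2 gives 310 nM, and it stands alone as the reference point, with no second measured compound against which a step could be computed.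

Compound 3 `CN(C)CCCCCCN(C)C1=Nc2ccccc2C(CC(=O)NCc2ccccc2)N1c1ccc(-c2ccccc2)cc1` differs from compound 2 in a single place: 2-(dimethylamino)ethyl in place of dimethylamino on a saturated chain carbon, four bonds along the chain from an amine nitrogen. The change lengthens the saturated chain on a saturated chain carbon, four bonds along the chain from an amine nitrogen, while the rest of the molecule is kept.

For the measured compounds named here, with no measured step in the set to guide the expectation, the account treats the chain extension as a small change. Compound 3 is expected to stay close to compound 2, with a step of a 1.0-fold lower number from compound 2 to compound 3 (0.01 log units; within the scatter) that is not expected to exceed the scatter in either direction. Compound 3 is therefore estimated at 300 nM, with a range from 100 nM to 900 nM.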

Compound 3, half-maximal inhibitory concentration: 550 nM
Estimate against measurement, compound 3: 1.8-fold (0.26 log units) below; the measured number falls inside the stated range.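

In this assay, among the compounds shown here, putting 2-(dimethylamino)ethyl in place of dimethylamino on a saturated chain carbon, four bonds along the chain from an amine nitrogen, gives a 1.8-fold higher number from compound 2 to compound 3 (0.25 log units; within the scatter) and so supplies the first measured step of the set. The step shows that, at this position and for this change, the read-out does not separate the longer chain from the shorter one: compound 2 and compound 3 cannot be told apart here, and this single pair gives no trend with chain length. No measurement shown bears on the reason for this outcome.

Compound 1 gives "not determined" (no result reported) in this assay and also differs from compound 2 and compound 3 in its distal aryl group, so the effect of that aryl group on the read-out cannot be read from the compounds shown. On these data alone, it also remains open whether a still longer chain, a shorter chain, or a piperidine or carboxylic acid at the chain end in place of the dimethylamino group would stay within the scatter of compound 2 or move beyond it.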